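Compound 2 to compound 3: swapping the aryl group

A few compounds are considered here, and "the series" means these few. Any claim that something is new, unique, unknown or untested is made for them only; others in the source may bear on it.

In a functional assay on SR cells (Homo sapiens) for inhibition, read by sulforhodamine B assay, with a stated time of 48 h (on this read-out lower numbers stand for stronger inhibition of growth and higher numbers for weaker inhibition of growth), compound 1 `Cc1ccc(C2=NN(c3ccc(S(C)(=O)=O)cc3)C(=O)CC2)cc1` gives 290 nM. Compound 2 `Cc1cc(O)ccc1C1=NN(c2ccc(S(C)(=O)=O)cc2)C(=O)CC1` gives 3390 nM, the higher of the two numbers and thus the weaker growth inhibition. For the measured compounds named here, only one measured step bears on the next change: a 12-fold higher number from compound 1 to compound 2 (1.07 log units; beyond the scatter), with 4-hydroxy-2-methylphenyl in place of 4-methylphenyl, a large step beyond the scatter.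

Compound 3 `CCc1ccc(C2=NN(c3ccc(S(C)(=O)=O)cc3)C(=O)CC2)cc1` differs from compound 2 as follows: 4-ethylphenyl in place of 4-hydroxy-2-methylphenyl on a carbon with a double bond to nitrogen. The entering 4-ethylphenyl resembles the 4-methylphenyl of compound 1, at 290 nM, more closely than it resembles the group that leaves. Going by the values given here, no measurement yet covers the ethyl group itself, so the range stays wide.

The expected change is a large one toward a lower number, a 9.7-fold lower number from compound 2 to compound 3 (0.99 log units; beyond the scatter). Compound 3 is estimated at 350 nM, with an expected range of 120 nM to 1000 nM.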

Compound 3, concentration for 50% growth inhibition: 5650 nM
Estimate against measurement, compound 3: 16-fold (1.21 log units) below; the whole stated range lies below it.
By their numbers in this assay, from the lowest: compound 1; then compounds 2 and 3 (each within the scatter of the next).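

In this assay the 4-methylphenyl of compound 1 proves hard to extend: methyl in place of hydrogen on the saturated chain carbon bound to an aromatic carbon gives a 19-fold higher number from compound 1 to compound 3 (1.29 log units; beyond the scatter), so 4-ethylphenyl does not stay with 4-methylphenyl on this carbon with a double bond to nitrogen. Against the other changed compound the reading is a 1.7-fold higher number from compound 2 to compound 3 (0.22 log units; within the scatter), which leaves 4-ethylphenyl and 4-hydroxy-2-methylphenyl not separable here, although only the latter carries a hydroxyl group. No supporting measurement is available to account for the step from the methyl to the ethyl group.

Open, from the compounds shown here alone, is whether plain phenyl or 4-fluorophenyl on this carbon would stay with compound 1. Also open, going by these compounds, is how 4-methoxyphenyl or 4-hydroxyphenyl, without the 2-methyl group, would read.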